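From naphthalen-1-yl to 2-chloropyridin-4-yl on the shared core

This account rests on a few compounds, and the source may have more. Where it says the series, first, only, none or still open, it means among the compounds named here.

In a functional assay on MDA-MB-436 cells (Homo sapiens) for antiproliferative activity, read by MTT assay, with a stated time of 48 h (on this read-out higher numbers stand for weaker inhibition and lower numbers for stronger inhibition), compound 1 (`C=CS(=O)(=O)N1CCN(c2ncnc3sc(-c4ccc(C(F)(F)F)cc4)cc23)CC1`) gives 7080 nM, compound 2 (`C=CS(=O)(=O)N1CCN(c2ncnc3sc(-c4ccc(OC)cc4)cc23)CC1`) gives 28400 nM and compound 3 (`C=CS(=O)(=O)N1CCN(c2ncnc3sc(-c4cccc5ccccc45)cc23)CC1`) gives 28100 nM. Compound 3 stands level with compound 2 at the high end of these three numbers, as a 1.0-fold lower number from compound 2 to compound 3 (0.00 log units; within the scatter) shows. Compound 1 alone stands apart, with a 4.0-fold higher number from compound 1 to compound 3 (0.60 log units; beyond the scatter) and a 4.0-fold higher number from compound 1 to compound 2 (0.60 log units; beyond the scatter).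

Compound 4 (`C=CS(=O)(=O)N1CCN(c2ncnc3sc(-c4ccnc(Cl)c4)cc23)CC1`) carries 2-chloropyridin-4-yl in place of naphthalen-1-yl on the same aromatic carbon, next to the ring sulfur: 2-chloropyridin-4-yl in place of naphthalen-1-yl on an aromatic carbon. Within the data shown here, no measured step introduces a ring nitrogen or a chlorine, so the evidence is indirect. The single-ring groups of compound 1 and compound 2 give different numbers, so having one ring does not settle the outcome. The measured swaps at this carbon reach no further than a 4.0-fold higher number from compound 1 to compound 3 (0.60 log units; beyond the scatter), which caps the expected size. The expected change is a 1.9-fold lower number from compound 3 to compound 4 (0.27 log units; within the scatter), a small move towards stronger inhibition, near the edge of the scatter. For compound 4 the estimated value is 15000 nM, with an expected range of 6000 nM to 35000 nM.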

Compound 4, half-maximal inhibitory concentration: 30100 nM
Beside the measured number, compound 4's estimate is 2.0-fold (0.30 log units) below it; measured number inside the range.
By their numbers in this assay, from the lowest: compound 1; then compounds 3, 2 and 4 (each within the scatter of the next).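

In this assay, 2-chloropyridin-4-yl on this aromatic carbon next to the ring sulfur gives a number within the scatter of naphthalen-1-yl (a 1.1-fold higher number from compound 3 to compound 4 (0.03 log units; within the scatter)) and of 4-methoxyphenyl (a 1.1-fold higher number from compound 2 to compound 4 (0.03 log units; within the scatter)), so a ring nitrogen and a chlorine on a single ring do not separate from either group. Compound 1 alone remains apart, with its 4-(trifluoromethyl)phenyl group (a 4.3-fold higher number from compound 1 to compound 4 (0.63 log units; beyond the scatter)), and compounds 2, 3 and 4 now form one level despite their different groups. No measurement at hand accounts for this level.

From the compounds shown here alone, the ring nitrogen and the chlorine enter together, so what each contributes alone stays open. Also open, going by these compounds, is whether a 4-chlorophenyl group, or an amine or carboxylic acid on the aromatic ring, would stay at that level or come close to compound 1.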